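Fluoro to methyl on a nucleoside-linked bicyclic group

A few compounds are considered here, and "the series" means these few. Any claim that something is new, unique, unknown or untested is made for them only; others in the source may bear on it.

Compound 1 `CC(=O)OC[C@H]1O[C@@H](n2c(SCc3cc4cc(C)ccc4oc3=O)nc3cncnc32)[C@H](O)[C@@H]1O` gives 16000 nM
Compound 2 `O=c1oc2ccc(F)cc2cc1CSc1nc2cncnc2n1[C@@H]1O[C@H](CO)[C@@H](O)[C@H]1O` gives 36000 nM

In a functional assay on Huh-5-2 cells (Homo sapiens) for cytotoxicity, read by microscopy (on this read-out higher numbers stand for lower toxicity in this test and lower numbers for higher toxicity in this test), compound 2 stands at 36000 nM as the higher of the two numbers, and the gap down to compound 1 lies beyond the usual scatter. Compound 3 `Cc1ccc2oc(=O)c(CSc3nc4cncnc4n3[C@@H]3O[C@H](CO)[C@@H](O)[C@H]3O)cc2c1` has yet to be measured. It is compound 2 with one change: methyl in place of fluoro on an aromatic carbon gives methyl in place of fluoro on an aromatic carbon of a six-membered aromatic ring of carbon only. Among the compounds with values here, no measured pair differs in one place alone, so the data offer no direct guide to the size of this change. Within the data shown here, compound 1 at 16000 nM is the only other number and it lies lower, which tilts the expectation slightly downward in this assay without reaching past the scatter. The expected change is a 1.4-fold lower number from compound 2 to compound 3 (0.14 log units; within the scatter) and it should stay within the scatter. For compound 3 the estimated value is 26000 nM with 11000 nM to 60000 nM as the expected range.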

Compound 3, half-maximal cytotoxic concentration: 46000 nM
Beside the measured number, compound 3's estimate is 1.8-fold (0.25 log units) below it; measured number inside the range.
By their numbers in this assay, from the lowest: compound 1; then compounds 2 and 3 (each within the scatter of the next).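

In this assay, methyl in place of fluoro on an aromatic carbon of the six-membered aromatic ring of carbon only gives a 1.3-fold higher number from compound 2 to compound 3 (0.11 log units; within the scatter), so this swap at this place leaves the read-out within the usual scatter. Compound 3 also separates the two differences between compound 1 and compound 2: hydrogen in place of acetyl on an oxygen on a saturated carbon gives a 2.9-fold higher number from compound 1 to compound 3 (0.46 log units; beyond the scatter), which ties the lower number of compound 1 to the acetyl rather than to the methyl. Nothing at hand gives a reason for either step.

The compounds shown leave open whether a methoxy group or an amine on that aromatic carbon would also stay within the scatter. They also leave open whether acetyl on the same oxygen of compound 2 would give a step of similar size.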